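A few compounds are considered here, and "the series" means these few. Any claim that something is new, unique, unknown or untested is made for them only; others in the source may bear on it.

Measured compounds:
Compound 1 `O=C(Nc1ccccc1)[C@@H]1CCCN1S(=O)(=O)c1cccc2cccnc12`: 35600 nM
Compound 2 `CC(C)c1ccccc1NC(=O)[C@@H]1CCCN1S(=O)(=O)c1cccc2cccnc12`: 29900 nM
Compound 3 `O=C(Nc1ccc(Cl)cc1Cl)[C@@H]1CCCN1S(=O)(=O)c1cccc2cccnc12`: > 50000 nM

Compound 3 has no exact reading in an ADME assay on HEp-2 cells (Homo sapiens) for cytotoxicity; a higher number here means that more compound is tolerated, a lower number that less compound is tolerated: its > 50000 nM is a limit, not a number. Compound 4 `Cc1ccc(C)c(NC(=O)[C@@H]2CCCN2S(=O)(=O)c2cccc3cccnc23)c1` has 2,5-dimethylphenyl in place of 2,4-dichlorophenyl on an amide-type nitrogen. Three measured steps changed the same aromatic group. The first is a 1.2-fold lower number from compound 1 to compound 2 (0.08 log units; within the scatter). The second is an at least 1.4-fold higher number from compound 1 to compound 3 (0.14 log units; that floor lies within the scatter). The third is an at least 1.6-fold higher number from compound 2 to compound 3 (0.22 log units; that floor lies within the scatter). None of these steps goes beyond the scatter, so no clear change is expected here either. The expected change is an at least 1.3-fold lower number from compound 3 to compound 4 (0.11 log units; that floor lies within the scatter). For compound 4 the estimated value is 38000 nM, with an expected range from 20000 nM to 50000 nM.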

Compound 4, half-maximal cytotoxic concentration: 30900 nM
The estimate for compound 4 lay 1.2-fold (0.09 log units) above the measured number; measured number inside the range.
By their numbers in this assay, from the lowest: compounds 2, 4 and 1 (each within the scatter of the next). At a limit, above all of these: compound 3.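

In this assay, 2,5-dimethylphenyl on the amide-type nitrogen gives no clear change from phenyl or from 2-isopropylphenyl, with a 1.2-fold lower number from compound 1 to compound 4 (0.06 log units; within the scatter) and a 1.0-fold higher number from compound 2 to compound 4 (0.01 log units; within the scatter). Against 2,4-dichlorophenyl there is an at least 1.6-fold lower number from compound 3 to compound 4 (0.20 log units; that floor lies within the scatter), which is only a floor, since compound 3 has a limit and not a number: the limit of > 50000 nM in this assay, at which 1 of the 4 values shown sits. Compound 1, compound 2 and compound 4 thus sit within the scatter of each other, while compound 3 stays unplaced.

Going by these compounds, the actual number for compound 3 remains open. So does whether an aromatic ring carrying an amine or a carboxylic acid would move the number beyond the scatter.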